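The source may hold more compounds than are shown below. What is called first, only, known or untested is meant among the compounds shown, and "the series" means these compounds.

Of the compounds shown here, three with a shared core have been measured in an assay (Cricetulus griseus) for inhibition of aldehyde dehydrogenase, mitochondrial (Homo sapiens); a higher number here means a weaker inhibitor, a lower number a stronger inhibitor. Compound 1 `CCOc1ccc2c(=O)c(-c3ccc(O)cc3)coc2c1` gives 80 nM. Compound 2 `NCCCCOc1ccc2c(=O)c(-c3ccc(O)cc3)coc2c1` gives 250 nM. Compound 3 `O=c1c(-c2ccc(O)cc2)coc2cc(OCCCCCCO)ccc12` gives 120 nM, which places it second highest of the three, with a 1.5-fold higher number from compound 1 to compound 3 (0.18 log units; within the scatter) and a 2.1-fold lower number from compound 2 to compound 3 (0.32 log units; beyond the scatter) as its two relations.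

Compound 4 `CC(C)Oc1ccc2c(=O)c(-c3ccc(O)cc3)coc2c1` differs from compound 3 by isopropyl in place of 6-hydroxyhexyl on an oxygen on an aromatic ring, which removes the hydrogen-bond donor and acceptor of the chain and leaves a short branched group in its place. The step that bears most directly on this is a 1.5-fold higher number from compound 1 to compound 3 (0.18 log units; within the scatter), which shows that lengthening the chain with a 4-hydroxybutyl end barely moved the number; reversing it should therefore cost little. The branching from ethyl to isopropyl has no measured counterpart among these compounds, so its effect is unknown. Compound 4 is expected to land close to compound 1, with a 1.3-fold lower number from compound 3 to compound 4 (0.12 log units; within the scatter) as the expected step. The estimate for compound 4 in this assay is 90 nM, with a range from 40 nM to 220 nM.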

Compound 4, half-maximal inhibitory concentration: 80 nM
For compound 4 the middle estimate is 1.1-fold (0.05 log units) above the measured one; low and high end bracket the measured number.
By their numbers in this assay, from the lowest: compounds 1, 4 and 3 (each within the scatter of the next); then compound 2.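

In this assay the added methyl on the saturated chain carbon bound to the oxygen on an aromatic ring gives no change at the digits printed from compound 1 to compound 4 (within the scatter) and so shows that this carbon, not only the far end of the chain, tolerates a change, with isopropyl reading the same as the ethyl of compound 1. Replacing the 6-hydroxyhexyl gives a 1.5-fold lower number from compound 3 to compound 4 (0.18 log units; within the scatter) and so a short branched group and a long chain ending in a hydroxyl cannot be told apart on this oxygen, while replacing the 4-aminobutyl gives a 3.1-fold lower number from compound 2 to compound 4 (0.49 log units; beyond the scatter) and leaves compound 2 as the only one of the four set apart from the others. Nothing available here explains why the 4-aminobutyl group stands apart.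

The 4-aminobutyl and 6-hydroxyhexyl groups differ in both chain length and end group, so a 6-aminohexyl or a 4-hydroxybutyl chain would be needed to separate the two. As far as these compounds go, how far branching can go on this oxygen also remains open, as does whether a tert-butyl or cyclopentyl group, or a carboxylic acid at the end of a chain, would read like compound 4 or like compound 2.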